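Lengthening the chain from propyl to butyl

This account rests on a few compounds, and the source may have more. Where it says the series, first, only, none or still open, it means among the compounds named here.

Compound 1 `O=C1CCC(O)(c2cccc(C(F)(F)F)c2)N1` gives > 200 mg/kg (a limit, not a number)
Compound 2 `CN1C(=O)CCC1(O)c1cccc(C(F)(F)F)c1` gives 51.6 mg/kg (a measured number)
Compound 3 `CCCN1C(=O)CCC1(O)c1cccc(C(F)(F)F)c1` gives 150 mg/kg (a measured number)

In a functional assay on the whole organism with Mus musculus as the target (on this read-out higher numbers stand for an effect only at larger amounts of compound and lower numbers for an effect already at smaller amounts), compound 3 holds the higher of the two actual numbers, while compound 1 offers only a limit. Compound 4 `CCCCN1C(=O)CCC1(O)c1cccc(C(F)(F)F)c1` turns the propyl on the amide-type nitrogen into butyl (methyl in place of hydrogen on a saturated chain carbon, three bonds along the chain from an amide-type nitrogen in a ring) and leaves the shared core unchanged. Within the data shown here, the closest precedent is the move from methyl to propyl (a 2.9-fold higher number from compound 2 to compound 3 (0.46 log units; beyond the scatter)), which went upward. The move from hydrogen to methyl ran the other way (an at least 3.8-fold lower number from compound 1 to compound 2 (0.58 log units; beyond the scatter)), and the move from hydrogen to propyl (an at least 1.3-fold lower number from compound 1 to compound 3 (0.12 log units; that floor lies within the scatter)) sets only a floor, so these compounds show no single trend. Butyl adds less to propyl than propyl added to methyl, so a smaller upward move is expected. The expected change is a 1.3-fold higher number from compound 3 to compound 4 (0.10 log units; within the scatter) in this estimate. For compound 4 the estimated value is 190 mg/kg within an expected range from 90 mg/kg to 400 mg/kg in this assay, and a result given only as a limit would not surprise.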

Compound 4, dose for half-maximal effect: 183 mg/kg
Compound 4: the middle estimate sits 1.0-fold (0.02 log units) above what was measured, and the stated range covers the measured number.
By their numbers in this assay, from the lowest: compound 2; then compounds 3 and 4 (each within the scatter of the next). At a limit, above all of these: compound 1.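

In this assay, going from propyl to butyl, with a methyl in place of hydrogen on a saturated chain carbon three bonds along the chain from an amide-type nitrogen in a ring, leaves the two numbers indistinguishable (a 1.2-fold higher number from compound 3 to compound 4 (0.09 log units; within the scatter)). The rise seen from methyl to propyl therefore does not continue measurably at butyl, although compound 4 remains clearly apart from the methyl compound (a 3.5-fold higher number from compound 2 to compound 4 (0.55 log units; beyond the scatter)). Against the parent with the amide hydrogen only a floor can be read (an at least 1.0-fold lower number from compound 1 to compound 4 (0.03 log units; that floor lies within the scatter)), and compound 1 stands at a limit: the limit of > 200 mg/kg in this assay, at which 1 of the 4 values shown sits.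

The compounds shown leave open whether a longer chain than butyl would stay with compounds 3 and 4. They also leave open whether an ethyl group, a benzyl group or a chain ending in an amine on this nitrogen would fall nearer compound 2.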